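Fluoro in place of cyclohexyl on the aminopyrimidine series

A few compounds are considered here, and "the series" means these few. Any claim that something is new, unique, unknown or untested is made for them only; others in the source may bear on it.

Two compounds of the shared core have been run in a functional assay (aorta) with Oryctolagus cuniculus as the target; on this read-out higher numbers stand for weaker inhibition and lower numbers for stronger inhibition. Compound 1 `Nc1nc(-c2nn(Cc3ccccc3F)c3ncccc23)ncc1C1CCC1` gives 633000 nM in this assay. Compound 2 `Nc1nc(-c2nn(Cc3ccccc3F)c3ncccc23)ncc1C1CCCCC1` gives 561000 nM in this assay. Among the compounds with values here, the only single-point change measured so far is cyclohexyl in place of cyclobutyl on an aromatic carbon, and this step, a 1.1-fold lower number from compound 1 to compound 2 (0.05 log units; within the scatter), leaves the two values within the scatter of each other; compound 2 therefore stands level with compound 1 and carries no separate claim of its own.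

Compound 3 `Nc1nc(-c2nn(Cc3ccccc3F)c3ncccc23)ncc1F` is not yet measured. It differs from compound 2 as follows: fluoro in place of cyclohexyl on an aromatic carbon. Within the data shown here, no measured step replaces a carbocyclic ring by a single fluorine, so the one step on hand bears on it only indirectly: changing the ring from cyclobutyl to cyclohexyl moved the number by a 1.1-fold lower number from compound 1 to compound 2 (0.05 log units; within the scatter), which is no movement beyond the scatter. On that basis no step beyond the scatter is expected for a 1.1-fold higher number from compound 2 to compound 3 (0.03 log units; within the scatter), but the range is kept wide. Compound 3 is estimated at 600000 nM in this assay, expected between 200000 nM and 1800000 nM.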

Compound 3, half-maximal inhibitory concentration: 478000 nM
The estimate for compound 3 lay 1.3-fold (0.10 log units) above the measured number; the range from low to high includes it.
By their numbers in this assay, from the lowest: compounds 3, 2 and 1 (each within the scatter of the next).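

In this assay, the aromatic carbon ortho to an amino group takes fluoro in place of either carbocyclic ring with no step beyond the scatter: fluoro in place of cyclohexyl gives a 1.2-fold lower number from compound 2 to compound 3 (0.07 log units; within the scatter), and fluoro in place of cyclobutyl gives a 1.3-fold lower number from compound 1 to compound 3 (0.12 log units; within the scatter). The earlier pair compared only two carbon rings, whereas these steps set a single fluorine against a ring of carbon only, and compounds 1, 2 and 3 still read level, so among these three the size of the group at this position does not separate the numbers. The data on hand offer no explanation for this level reading.

From the compounds shown here alone, it remains open whether any group at this position can move the number beyond the scatter, for example an amine, a carboxylic acid, a methoxy group or a longer alkyl chain. Going by these compounds, it is also open whether the level reading at this position would hold if another part of the shared core were changed.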